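The source may hold more compounds than are shown below. What is called first, only, known or untested is meant among the compounds shown, and "the series" means these compounds.

Measured so far in a functional assay on DU-145 cells (Homo sapiens) for inhibition, read by trypan blue exclusion, with a stated time of 96 h; on this read-out lower numbers stand for stronger inhibition of growth and higher numbers for weaker inhibition of growth:
Compound 1 `COc1ccccc1/C=C(/Sc1ccc(C)cc1)C(=O)c1ccc(Cl)cc1` gives 25000 nM.
Compound 2 `Cc1ccc(S/C(=C/c2cc(C)cc(C)c2)C(=O)c2ccc(Cl)cc2)cc1` gives 50000 nM.
Compound 3 `Cc1ccc(S/C(=C/c2ccc(N(C)C)cc2)C(=O)c2ccc(Cl)cc2)cc1` gives only a limit, > 100000 nM.

Compound 3 thus sits at the weak end of the numbers shown, and its value is a limit of this assay rather than a number (the limit of > 100000 nM in this assay, at which 1 of the 3 values shown sits). Compound 4 `Cc1ccc(S/C(=C/c2ccc(Cl)cc2Cl)C(=O)c2ccc(Cl)cc2)cc1` differs from compound 3 by 2,4-dichlorophenyl in place of 4-(dimethylamino)phenyl on a double-bonded chain carbon bound to a double-bonded chain carbon. The measured steps that bear on this are an at least 4.0-fold higher number from compound 1 to compound 3 (0.60 log units; beyond the scatter) and an at least 2.0-fold higher number from compound 2 to compound 3 (0.30 log units; that floor lies within the scatter): in both, the compound without the 4-(dimethylamino)phenyl group gives the lower number. Given an at least 4.0-fold higher number from compound 1 to compound 3 (0.60 log units; beyond the scatter), the step of an at least 3.3-fold lower number from compound 3 to compound 4 (0.52 log units; beyond the scatter) is expected to run downward, back toward the numbers of compound 1 and compound 2. Compound 4 is therefore estimated at 30000 nM, with a range of 10000 nM to 100000 nM.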

Compound 4, concentration for 50% growth inhibition: 10000 nM
Compound 4: middle estimate off by 3.0-fold (0.48 log units), on the high side, within the range that was stated.
By their numbers in this assay, from the lowest: compound 4; then compounds 1 and 2 (each within the scatter of the next). At a limit, above all of these: compound 3.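

In this assay, 2,4-dichlorophenyl gives the lowest number of the four, with a 5.0-fold lower number from compound 2 to compound 4 (0.70 log units; beyond the scatter) and a 2.5-fold lower number from compound 1 to compound 4 (0.40 log units; beyond the scatter). Among these compounds, the two measured numbers available before lay within the scatter of each other, so this is the first change at this place that separates measured values. Against 4-(dimethylamino)phenyl the change reads an at least 10-fold lower number from compound 3 to compound 4 (1.00 log units; beyond the scatter), which is only a floor, as compound 3 stands at a limit and not at a number: the limit of > 100000 nM in this assay, at which 1 of the 4 values shown sits.

As far as these compounds go, whether both chlorines are needed remains open. From the compounds shown here alone, how a plain phenyl, an amine or a carboxylic acid would read at this place also remains open.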